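Swapping 2-Hydroxyphenyl for 2-Phenylethenyl: Lipophilicity Outlook

The source may hold more compounds than are shown below. What is called first, only, known or untested is meant among the compounds shown, and "the series" means these compounds.

Measured so far:
- compound 1, `O=C(CN1C(=O)c2ccccc2C1=O)NN1C(=O)CSC1c1c(F)cccc1Cl`: 3.79
- compound 2, `Cc1ccc(C2SCC(=O)N2NC(=O)CN2C(=O)c3ccccc3C2=O)cc1`: 2.97
- compound 3, `O=C(CN1C(=O)c2ccccc2C1=O)NN1C(=O)CSC1c1ccccc1O`: 1.46

All three share the same core and differ only in the group on a saturated ring carbon. In a physicochemical assay for lipophilicity, in phosphate buffer, measured as octanol-water partition, with a stated time of 24 h (on this read-out lower numbers stand for lower lipophilicity and higher numbers for higher lipophilicity), compound 3 gives 1.46, the lowest of the three numbers. Its nearest neighbour is compound 2, and the step of a number 1.51 log units lower from compound 2 to compound 3 (beyond the scatter); the furthest is compound 1, with the step of a number 2.33 log units lower from compound 1 to compound 3 (beyond the scatter). Both steps lie beyond the scatter, so the 2-hydroxyphenyl compound stands clearly apart.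

Compound 4, `O=C(CN1C(=O)c2ccccc2C1=O)NN1C(=O)CSC1/C=C/c1ccccc1`, has not yet been measured. It differs from compound 3 as follows: 2-phenylethenyl in place of 2-hydroxyphenyl on a saturated ring carbon

Among the compounds with values here, the steps that bear on this change are those into compound 3, since both exchange the 2-hydroxyphenyl group for a group without a hydroxyl: a number 2.33 log units lower from compound 1 to compound 3 (beyond the scatter) and a number 1.51 log units lower from compound 2 to compound 3 (beyond the scatter). Reversing that exchange, a rise in this assay of roughly the size seen from compound 2 to compound 3 is expected, giving for compound 4 an expected step of a number 1.74 log units higher from compound 3 to compound 4 (beyond the scatter). The estimate for compound 4 is therefore 3.2, in a range from 2.6 to 3.8.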

Compound 4, partition coefficient: 3.65
The estimate for compound 4 lay 0.45 log units below the measured number; low and high end bracket the measured number.
By their numbers in this assay, from the lowest: compound 3; then compound 2; then compounds 4 and 1 (each within the scatter of the next).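

Within the data shown here, of the groups so far, 2-hydroxyphenyl is the only one that leaves the number low in this assay: exchanging it for 2-phenylethenyl, which has no hydrogen-bond donor, gives a number 2.19 log units higher from compound 3 to compound 4 (beyond the scatter) and so restores a high value. This position also accepts a group with a double bond outside the aromatic ring without a return to the level of compound 2, with a number 0.68 log units higher from compound 2 to compound 4 (beyond the scatter) as the step, while the comparison with the halogenated group gives a number 0.14 log units lower from compound 1 to compound 4 (within the scatter) and so separates neither compound from the other. These numbers describe what happens at this position, but nothing shown here accounts for them.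

A 2-phenylethyl group, the same chain with its double bond saturated, would show whether that bond itself matters or whether the carbon count and the aromatic ring are enough. A 2-methoxyphenyl group would ask whether the low value of compound 3 depends on the hydrogen of its hydroxyl, and an amine or a carboxylic acid on the same ring would show how much further the number can move.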